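The source may hold more compounds than are shown below. What is called first, only, known or untested is meant among the compounds shown, and "the series" means these compounds.

Compound 1 `CCCNc1ccc(NC(=O)c2cc(Cl)ccc2O)c(Cl)c1` gives 22500 nM in an ADME assay on A549 cells (Homo sapiens) for cytotoxicity, read by resazurin assay, with a stated time of 48 h; on this read-out higher numbers stand for lower toxicity in this test and lower numbers for higher toxicity in this test.
Compound 2 `CC1(Nc2ccc(NC(=O)c3cc(Cl)ccc3O)c(Cl)c2)CCCC1` gives 157000 nM in this assay.
Compound 3 `O=C(Nc1ccc(NCc2ccc(Cl)cc2)cc1Cl)c1cc(Cl)ccc1O` gives 59700 nM in this assay.

Compound 3 stands second highest of the three numbers: a 2.6-fold lower number from compound 2 to compound 3 (0.42 log units; beyond the scatter), while a 2.7-fold higher number from compound 1 to compound 3 (0.42 log units; beyond the scatter). Compound 4 `O=C(Nc1ccc(NCc2ccc(O)nc2)cc1Cl)c1cc(Cl)ccc1O` is the next step, and the change is 6-hydroxypyridin-3-yl in place of 4-chlorophenyl on a saturated chain carbon bound to a nitrogen on an aromatic ring. Among the measured compounds shown here, both measured steps at this place on the nitrogen, the one from compound 1 to compound 3 and the one from compound 2 to compound 3, were modest, and none of them swaps one aromatic ring for another, so no step of that kind has been seen. A small step is therefore expected in this assay, leaning toward a higher number. For compound 4 the estimate is 90000 nM, within 30000 nM to 270000 nM, which means an expected 1.5-fold higher number from compound 3 to compound 4 (0.18 log units; within the scatter).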

Compound 4, half-maximal cytotoxic concentration: 98500 nM
Compound 4: the middle estimate sits 1.1-fold (0.04 log units) below what was measured; low and high end bracket the measured number.
By their numbers in this assay, from the lowest: compound 1; then compounds 3, 4 and 2 (each within the scatter of the next, the first and the last beyond it).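

In this assay, 6-hydroxypyridin-3-yl in place of 4-chlorophenyl is the only swap shown of one aromatic ring for another at this place, and it stays within the scatter (a 1.6-fold higher number from compound 3 to compound 4 (0.22 log units; within the scatter)). The (6-hydroxypyridin-3-yl)methyl group also lies within the scatter of 1-methylcyclopentyl (a 1.6-fold lower number from compound 2 to compound 4 (0.20 log units; within the scatter)), while the step from the propyl group lies beyond it (a 4.4-fold higher number from compound 1 to compound 4 (0.64 log units; beyond the scatter)). Nothing here explains these numbers. Still open, going by these compounds, is how a plain pyridin-3-yl ring, without the hydroxy group, would read at this place, or a chain ending in an amine or a carboxylic acid.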